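A few compounds are considered here, and "the series" means these few. Any claim that something is new, unique, unknown or untested is made for them only; others in the source may bear on it.

The account concerns compound 2 `C#CCCOC(=O)c1ccc(C(CC)(CC)c2ccc(OCCC(O)(CC)CC)c(C)c2)n1CC` and the untested compound 4 `CCn1c(C(=O)N(C)CCO)ccc1C(CC)(CC)c1ccc(OCCC(O)(CC)CC)c(C)c1`, both built on the core of compound 1 `CCn1c(C(=O)NCCCN(C)C)ccc1C(CC)(CC)c1ccc(OCCC(O)(CC)CC)c(C)c1`. In a functional assay on Caco-2 cells (Homo sapiens) for antiproliferative activity, read by MTT assay, with a stated time of 48 h (a higher number here means a weaker inhibitor, a lower number a stronger inhibitor), compound 1 gives 490 nM. Compound 2 reaches only a limit in this assay, > 50000 nM. Compound 2 thus stands at the limit of > 50000 nM in this assay, at which 1 of the 3 values shown sits. Compound 3 `CCn1c(C(=O)NC(CC(=O)O)C(=O)OC)ccc1C(CC)(CC)c1ccc(OCCC(O)(CC)CC)c(C)c1` gives 25200 nM in this assay. The measured steps are an at least 100-fold higher number from compound 1 to compound 2 (2.00 log units; beyond the scatter) and a 51-fold higher number from compound 1 to compound 3 (1.71 log units; beyond the scatter), while an at least 1.9-fold lower number from compound 2 to compound 3 (0.29 log units; that floor lies within the scatter). The change to compound 4 is (2-hydroxyethyl)(methyl)amino in place of (but-3-yn-1-yl)oxy on a carbonyl carbon. It turns an ester into an amide, as in compound 1 at 490 nM and compound 3 at 25200 nM; yet compound 4 lacks the (3-(dimethylamino)propyl)amino of compound 1 and matches neither amide closely. A number below the limit of compound 2 is therefore expected, though not near compound 1. Compound 4 is estimated at 15000 nM, between 3000 nM and 50000 nM. This estimate means an expected at least 3.3-fold lower number from compound 2 to compound 4 (0.52 log units; beyond the scatter).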

Compound 4, half-maximal inhibitory concentration: 74 nM
Estimate against measurement, compound 4: 200-fold (2.31 log units) above, outside the stated range (below it).
By their numbers in this assay, from the lowest: compound 4; then compound 1; then compound 3. At a limit, above all of these: compound 2.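

On this carbonyl carbon, (2-hydroxyethyl)(methyl)amino in place of (but-3-yn-1-yl)oxy gives an at least 670-fold lower number from compound 2 to compound 4 (2.82 log units; beyond the scatter) in this assay, a far larger change than the earlier amides suggested. Compound 2 stands only at a limit: the limit of > 50000 nM in this assay, at which 1 of the 4 values shown sits.

The amine end of compound 1 is not required for a low number, as the step to the uncharged group shows a 6.6-fold lower number from compound 1 to compound 4 (0.82 log units; beyond the scatter), while the group on the amide nitrogen decides much of the result, as the amides show with a 340-fold lower number from compound 3 to compound 4 (2.53 log units; beyond the scatter).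

Which part of (2-hydroxyethyl)(methyl)amino counts, the hydroxyl or the methyl on nitrogen, remains open. So does how a longer hydroxyalkyl chain or a morpholine on this carbonyl carbon would read in this assay.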